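The source may report more compounds than this note shows. Statements on the series, on what has been measured and on what is new or still open speak of the compounds shown alone.

Measured compounds:
Compound 1 `CC(=O)O[C@H]1CC[C@]2(C)[C@H](CC[C@@](C)(O)[C@H]2CC[C@@H]2C(C)=CC[C@@H]3C(C)=CC[C@@H]3C2(C)C)OC1(C)C` — in a functional assay on MDA-MB-231 cells (Homo sapiens) for antiproliferative activity, read by MTT assay, with a stated time of 72 h (a lower number here means a stronger inhibitor, a higher number a weaker inhibitor), compound 1 gives 39200 nM
Compound 2 `CC1=CC[C@H]2[C@H](CC[C@]2(C)O)C(C)(C)[C@@H]1CC[C@H]1[C@]2(C)CC[C@H](OCc3ccccc3)C(C)(C)O[C@H]2CC[C@@]1(C)O` — in this assay compound 2 gives 29100 nM

Among the compounds with values here, compound 2 and compound 1 are the only two measured compounds, and the gap between their numbers lies within the scatter of repeated measurement, so compound 2 does not stand apart from compound 1 in this assay. Both compounds are weak inhibitors in this setting.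

Compound 3 `CC1=CC[C@H]2[C@H](CC[C@]2(C)O)C(C)(C)[C@@H]1CC[C@H]1[C@]2(C)CC[C@H](OC(=O)c3ccco3)C(C)(C)O[C@H]2CC[C@@]1(C)O` is built from compound 2 by one change: (furan-2-yl)carbonyl in place of benzyl on an oxygen on a saturated carbon. The oxygen on the saturated carbon is kept; only the group on it is exchanged, benzyloxy becoming ((furan-2-yl)carbonyl)oxy.

Within the data shown here, no step between measured compounds bears on this exchange, so there is nothing measured that points in either direction. The step from compound 2 to compound 3 is therefore expected to be small, a 1.2-fold lower number from compound 2 to compound 3 (0.07 log units; within the scatter), with no change beyond the scatter. Compound 3 is estimated to give 25000 nM in this assay, expected between 9000 nM and 70000 nM.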

Compound 3, half-maximal inhibitory concentration: 14000 nM
Compound 3: the middle estimate sits 1.8-fold (0.25 log units) above what was measured; the measured number falls inside the stated range.
By their numbers in this assay, from the lowest: compound 3; then compounds 2 and 1 (each within the scatter of the next).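

Within the data shown here, the group on the oxygen on a saturated carbon does move the number in this assay: the exchange of benzyl for (furan-2-yl)carbonyl gives a 2.1-fold lower number from compound 2 to compound 3 (0.32 log units; beyond the scatter) and is the first step here to lie beyond the scatter, though it is only modest. Both groups count 7 heavy atoms, while the entering group brings a five-membered aromatic ring with 1 hetero atom, a double bond outside aromatic rings and 2 hydrogen-bond acceptors, so this single step changes several things at once. No measurement at hand accounts for the step.

As far as these compounds go, whether the step goes with the carbonyl or with the furan ring remains open. A benzoyl or a (furan-2-yl)methyl group on the same oxygen would separate the two.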